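A Methyl in Place of Chloro on an Aromatic Carbon

A few compounds are considered here, and "the series" means these few. Any claim that something is new, unique, unknown or untested is made for them only; others in the source may bear on it.

In a functional assay on L1210 cells (Mus musculus) for inhibition, read by cell counting, with a stated time of 48 h (a higher number here means a weaker inhibitor, a lower number a stronger inhibitor), compound 1 (`CCN(CC)CN1C(=O)/C(=N/NC(=S)Nc2ccccc2)c2cc(Cl)ccc21`) gives 49000 nM and compound 2 (`CCN(CC)CN1C(=O)/C(=N/NC(=S)Nc2ccc(Cl)cc2)c2ccccc21`) gives 11000 nM as the lower of the two numbers. For the measured compounds named here, the gap between these two compounds lies beyond the usual scatter, which places compound 2 ahead of the only other measured compound. Compound 3 (`CCN(CC)CN1C(=O)/C(=N/NC(=S)Nc2ccc(C)cc2)c2ccccc21`) is still unmeasured and differs from compound 2 by methyl in place of chloro on an aromatic carbon at a site para to a large group. Going by the values given here, no measured pair shows this exchange, so the expectation starts from compound 2 at 11000 nM and allows a modest move toward a higher number, possibly none beyond the scatter. The expected change is the step of a 1.5-fold higher number from compound 2 to compound 3 (0.16 log units; within the scatter) and it remains an estimate. For compound 3 the estimated value is 16000 nM with an expected range from 6000 nM to 40000 nM in this test.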

Compound 3, half-maximal inhibitory concentration: 29000 nM
For compound 3 the middle estimate is 1.8-fold (0.26 log units) below the measured one; the measured number falls inside the stated range.
By their numbers in this assay, from the lowest: compound 2; then compounds 3 and 1 (each within the scatter of the next).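

Putting methyl in place of chloro on this aromatic carbon, para to a large group, gives a 2.6-fold higher number from compound 2 to compound 3 (0.42 log units; beyond the scatter) in this assay. The position therefore responds to the exchange, even though the two groups each have one heavy atom, no hydrogen-bond donor or acceptor, and no net charge. Nothing at hand accounts for the difference.

As far as these compounds go, it remains open how other groups on this carbon, such as methoxy, an amine or a carboxylic acid, would compare with the chloro of compound 2 and the methyl of compound 3. From the compounds shown here alone, it is also open whether the same exchange would give a step of similar size on the other aromatic ring of the shared core, where compound 1 carries its chloro.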